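The compounds below may be only part of what the source reports. "The series", "measured", "known", "first", "only" and "open" are said of these compounds alone.

Measured so far in an ADME assay (Rattus norvegicus, strain Wistar Han) for pharmacokinetics; on this read-out higher numbers stand for wider distribution into tissues and lower numbers for narrower distribution:
- compound 1 `CCn1c(-c2cnc(C)nc2)nc2c(O[C@H]3CCN(C(=O)C4CC4)C3)ncnc21` gives 0.7 L/kg
- compound 2 `CCn1c(-c2cnc(C)nc2)nc2c(N[C@H]3CCN(C(=O)C4CCOC4)C3)ncnc21` gives 0.7 L/kg
- compound 3 `CCn1c(-c2ccc(C(F)(F)F)nc2)nc2c(O[C@H]3CCN(C(=O)[C@H]4C[C@@H](OC)C4)C3)ncnc21` gives 0.4 L/kg

All three compounds share the same core and differ only in the groups attached to it. Compound 2 and compound 1 return the same number at the digits shown, and the gap between compound 2 and compound 3 is within the usual scatter of repeated measurements, so the three numbers cannot be told apart with confidence on this read-out.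

Compound 4 `CCn1c(-c2cnc(C)nc2)nc2c(N[C@H]3CCN(C(=O)C4CCOCC4)C3)ncnc21` has not yet been measured. It differs from compound 2 in one place: oxan-4-yl in place of oxolan-3-yl on a carbonyl carbon. Going by the values given here, no measured pair among the three compounds shows a step of this kind, so nothing in the data points to a shift in either direction, and the change is a small one in ring size at the amide-type nitrogen in a ring.

The expected step of no change at the digits printed from compound 2 to compound 4 (within the scatter) is therefore none beyond the scatter. Compound 4 is estimated to give 0.7 L/kg, with a range from 0.4 L/kg to 1.2 L/kg.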

Compound 4, volume of distribution: 0.7 L/kg
For compound 4 middle estimate and measured number coincide at the digits printed; low and high end bracket the measured number.
By their numbers in this assay, from the lowest: compounds 3, 1, 2 and 4 (each within the scatter of the next).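

Going by these compounds alone, compounds 1 to 3 offered no pair differing in one place, so this is the first direct look at a single change in this assay. Putting oxan-4-yl in place of oxolan-3-yl on the carbonyl carbon gives no change at the digits printed from compound 2 to compound 4 (within the scatter) in this series. At this position, then, going from a five-membered to a six-membered non-aromatic ring with one oxygen does not separate the two compounds on this read-out, and no measurement shown offers an explanation for that result.

On these data alone, what stays open is whether a group of a different kind on this carbonyl carbon, such as an amine, a carboxylic acid or a longer chain, would separate from oxan-4-yl. As far as these compounds go, it is also open whether the same ring swap would give the same result in a compound that differs from compound 2 elsewhere.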